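The source may report more compounds than this note shows. Statements on the series, on what has been measured and on what is new or still open speak of the compounds shown alone.

Measured in a functional assay on MIA PaCa-2 cells (Homo sapiens) for inhibition, read by MTT assay, with a stated time of 3 days; on this read-out lower numbers stand for stronger inhibition and higher numbers for weaker inhibition:
compound 1 `CCN(CC)S(=O)(=O)c1ccc(S(=O)(=O)N2CCC[C@@H](C(=O)N[C@H]3CC[C@H](OC)CC3)C2)cc1`: 2290 nM
compound 2 `O=C([C@@H]1CCCN(S(=O)(=O)c2ccc(S(=O)(=O)C3CCC3)cc2)C1)N1CCC(F)(F)CC1`: 12.6 nM
compound 3 `CN(C)S(=O)(=O)c1ccc(S(=O)(=O)N2CCC[C@@H](C(=O)N3CCC(F)(F)CC3)C2)cc1`: 72.4 nM

Compound 1 gives the highest number of the three. Compound 4 `CCN(CC)S(=O)(=O)c1ccc(S(=O)(=O)N2CCC[C@@H](C(=O)N3CCC(COC)CC3)C2)cc1` differs from it as follows: 4-(methoxymethyl)piperidin-1-yl in place of (4-methoxycyclohexyl)amino on a carbonyl carbon. The amide hydrogen of compound 1 is therefore absent in compound 4, as it is in compound 2 and compound 3. Among the measured compounds shown here, the only measured step, a 5.7-fold higher number from compound 2 to compound 3 (0.76 log units; beyond the scatter), lies on a sulfonyl sulfur rather than on this carbonyl carbon, so it gives only a sense of scale. For the measured compounds named here, no measured pair isolates the change itself. A large fall is expected, resting on compound 3 at 72.4 nM, with wide margins. The expected step is a 15-fold lower number from compound 1 to compound 4 (1.18 log units; beyond the scatter). For compound 4 the estimate is 150 nM, with an expected range from 40 nM to 600 nM.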

Compound 4, half-maximal inhibitory concentration: 50 nM
For compound 4 the middle estimate is 3.0-fold (0.48 log units) above the measured one, within the range that was stated.
By their numbers in this assay, from the lowest: compound 2; then compounds 4 and 3 (each within the scatter of the next); then compound 1.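

In this assay, among the compounds shown here, replacing (4-methoxycyclohexyl)amino with 4-(methoxymethyl)piperidin-1-yl on the carbonyl carbon gives a 46-fold lower number from compound 1 to compound 4 (1.66 log units; beyond the scatter) and is the first measured step at this position. The atoms are the same and only their joining differs, so this position responds strongly to a rearrangement alone. Nothing available explains the size of this step.

The loss of the amide hydrogen and the new ring arrive together, so their shares remain unseparated. A methyl group on the amide nitrogen of compound 1 would test the amide hydrogen alone.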